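The source may report more compounds than this note shows. Statements on the series, on what has been measured and on what is new or still open speak of the compounds shown alone.

Working notes on the series, read in a functional assay on HL-60 cells (Homo sapiens) for cytotoxicity, read by WST assay, with a stated time of 48 h; on this read-out higher numbers stand for an effect only at larger amounts of compound and lower numbers for an effect already at smaller amounts. Compound 1 (`O=C1OC[C@H](Cc2ccccc2)[C@H]1Cc1cccc(O)c1`) gives > 100000 nM, which is a limit of the assay and not a number. Among the compounds with values here, compound 2 (`COc1cccc(C[C@H]2C(=O)OC[C@@H]2Cc2ccccc2)c1`) gives 66000 nM, the only actual number so far, so it has no measured value to be ranked against. Within the data shown here, the one measured step is an at least 1.5-fold lower number from compound 1 to compound 2 (0.18 log units; that floor lies within the scatter), with methyl in place of hydrogen on an oxygen on an aromatic ring. That step is known only as a floor because of the limit of > 100000 nM in this assay, at which 1 of the 2 values shown sits.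

Compound 3 (`O=C1OC[C@H](Cc2ccccc2)[C@H]1Cc1cccc(OC(F)(F)F)c1`) changes the same oxygen substituent, with trifluoromethyl in place of methyl on an oxygen on an aromatic ring. Among the measured compounds shown here, the step to compound 2 is the only guide at this place, and it concerns a different replacement, so it supports no sizeable shift. No change beyond the scatter is therefore expected in this assay, in either direction. The estimated step is a 1.5-fold lower number from compound 2 to compound 3 (0.17 log units; within the scatter). For compound 3 the expected value is 45000 nM, with an estimated range of 15000 nM to 100000 nM.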

Compound 3, half-maximal effective concentration: 34000 nM
Beside the measured number, compound 3's estimate is 1.3-fold (0.12 log units) above it, within the range that was stated.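

At this oxygen on the aromatic ring, the change from methoxy to trifluoromethoxy gives a 1.9-fold lower number from compound 2 to compound 3 (0.29 log units; within the scatter) in this assay, so these two capped forms are not separated on this read-out. Within the data shown here, the hydroxyl compound and the trifluoromethoxy compound are separated, with an at least 2.9-fold lower number from compound 1 to compound 3 (0.46 log units; beyond the scatter) as the first step at this position that is printed as beyond the scatter, whereas the step to the methoxy compound was not. From the compounds shown here alone, the series therefore now holds one comparison at this place that exceeds the usual variation, but the full size of that step remains unknown because it can be stated only as a floor: the limit of > 100000 nM in this assay, at which 1 of the 3 values shown sits.

Going by these compounds, whether a longer chain on this oxygen, such as ethoxy, or an amine or a carboxylic acid carried at this place would shift the number further remains open. The compounds shown also change only this one substituent, so they say nothing about replacements elsewhere on the shared core, or about whether the same ordering would hold in any other cell line.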